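A methoxy group added to a triazole hydrazone

The source may hold more compounds than are shown below. What is called first, only, known or untested is meant among the compounds shown, and "the series" means these compounds.

Compound 1 `O=[N+]([O-])c1ccc(CSc2nnc(-c3ccncc3)n2-c2ccccc2)cc1`: 23800 nM
Compound 2 `O=C(CSc1nnc(-c2ccncc2)n1-c1ccccc1)N/N=C/c1ccccc1`: 14700 nM

Of the compounds shown here, two have been measured in a functional assay on HCT-116 cells (Homo sapiens) for inhibition, read by MTT assay, with a stated time of 48 h; a higher number here means a weaker inhibitor, a lower number a stronger inhibitor. Compound 1 gives 23800 nM there, and compound 2 gives 14700 nM. Among the measured compounds shown here, compound 2 thus holds the lowest of the two numbers, yet its only neighbour, compound 1, lies within the scatter, so the two cannot be told apart on these values.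

Compound 3 `COc1ccc(/C=N/NC(=O)CSc2nnc(-c3ccncc3)n2-c2ccccc2)cc1` has not yet been measured. It differs from compound 2 in one place: methoxy in place of hydrogen on an aromatic carbon. For the measured compounds named here, no step between measured compounds shows how this assay answers such a change, so the expectation rests on compound 2 alone. The expected step is a 1.2-fold lower number from compound 2 to compound 3 (0.09 log units; within the scatter), a small move that is not expected to reach beyond the scatter. For compound 3 the estimated value in this assay is 12000 nM, with a range from 5000 nM to 30000 nM.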

Compound 3, half-maximal inhibitory concentration: 19200 nM
Estimate against measurement, compound 3: 1.6-fold (0.20 log units) below; low and high end bracket the measured number.
By their numbers in this assay, from the lowest: compounds 2, 3 and 1 (each within the scatter of the next).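

In this assay, among the compounds shown here, the step of a 1.3-fold higher number from compound 2 to compound 3 (0.12 log units; within the scatter) is the first reading of a single change between measured compounds. It shows that, on this aromatic carbon para to a large group, phenyl to 4-methoxyphenyl gives no readable shift in either direction, so compound 2 and compound 3 cannot be told apart on these values. No measurement shown here bears on this result.

What the compounds shown leave open is whether a different group at this place, such as an amine, a carboxylic acid or a longer alkoxy chain, would carry the number beyond the scatter. They also leave open whether methoxy would read the same way on another carbon of this ring.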